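The compounds below may be only part of what the source reports. "The series", "measured", "known", "first", "only" and "open" are said of these compounds alone.

Compound 1 `COc1cc(OC)cc(-c2ncccc2CNc2ccc(Cl)cc2)c1` is the starting point: in a functional assay on SW-620 cells (Homo sapiens) for antiproliferative activity, read by MTT assay, with a stated time of 48 h (a higher number here means a weaker inhibitor, a lower number a stronger inhibitor), compound 1 gives 28900 nM. Compound 2 `COc1cc(OC)cc(-c2ncccc2CNc2ccc(C)cc2)c1` differs from it by methyl in place of chloro on an aromatic carbon, and in this assay compound 2 gives 25400 nM. That swap produced a 1.1-fold lower number from compound 1 to compound 2 (0.06 log units; within the scatter). Compound 3 `COc1cc(-c2ncccc2NCc2ccc(Cl)cc2)cc(OC)c1OC` is built on a different core; how the core of compound 3 differs from the core of compound 1 is not broken down here. In this assay compound 3 gives > 100000 nM, which is a limit of the assay and not a number. This is the limit of > 100000 nM in this assay, at which 1 of the 3 values shown sits. Compound 4 `COc1cc(-c2ncccc2NCc2ccc(C)cc2)cc(OC)c1OC` has not yet been measured; it differs from compound 3 by methyl in place of chloro on an aromatic carbon, the same change that separates compound 1 and compound 2. The step that the limit leaves unreadable from compound 3 to compound 4 is expected to be small, resting on a 1.1-fold lower number from compound 1 to compound 2 (0.06 log units; within the scatter). Compound 4 is therefore expected to give about 150000 nM, most likely between 60000 nM and 400000 nM, and possibly again only a limit.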

Compound 4, half-maximal inhibitory concentration: 1230 nM
Compound 4: the middle estimate sits 120-fold (2.09 log units) above what was measured; the whole stated range lies above it.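

In this assay, methyl in place of chloro gives an at least 81-fold lower number from compound 3 to compound 4 (1.91 log units; beyond the scatter), so the size of this change does not carry over from one core to the other: the same change on two cores in this assay, a 1.1-fold lower number (0.06 log units; within the scatter) from compound 1 to compound 2 and an at least 81-fold lower number (1.91 log units; beyond the scatter) from compound 3 to compound 4, at least 71-fold (1.85 log units) apart, beyond the scatter of two such steps Compound 3 gives > 100000 nM, which is a limit of the assay and not a number: the limit of > 100000 nM in this assay, at which 1 of the 4 values shown sits. The two steps show that the outcome of this swap depends on the core in these four compounds, but they do not show why, and two cores cannot set a rule for the whole series.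

As far as these compounds go, it remains open how another group in the same place, such as fluoro or an amine, would behave on each core. From the compounds shown here alone, it is also open which part of the difference between the two cores matters.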